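Bromo for methyl on a fused triazolothiadiazole core

A few compounds are considered here, and "the series" means these few. Any claim that something is new, unique, unknown or untested is made for them only; others in the source may bear on it.

Compound 1 `Cc1ccc(NC(=S)Nn2c(S)nnc2-c2ccncc2)cc1` and compound 2 `S=C(Nc1ccc(Br)cc1)Nn1c(S)nnc1-c1ccncc1` share an open thiourea-linked core; in a functional assay on HepG2 cells (Homo sapiens) for cytotoxicity, read by sulforhodamine B assay, with a stated time of 24 h (a higher number here means a weaker inhibitor, a lower number a stronger inhibitor), compound 1 gives 1230 nM, and compound 2 gives 2780 nM. Going by the values given here, the single change between them, (bromo in place of methyl on an aromatic carbon), produced a step of a 2.3-fold higher number from compound 1 to compound 2 (0.35 log units; beyond the scatter). Compound 3 `Cc1ccc(Nc2nn3c(-c4ccncc4)nnc3s2)cc1` carries a fused core; how that core differs from the core of compound 1 is not broken down here. In this assay compound 3 gives 312 nM, the lowest of the three numbers. Compound 4 `Brc1ccc(Nc2nn3c(-c4ccncc4)nnc3s2)cc1` is compound 3 with the same change, (bromo in place of methyl on an aromatic carbon), made at the same place. Because the earlier step of a 2.3-fold higher number from compound 1 to compound 2 (0.35 log units; beyond the scatter) was modest but beyond the scatter, a similar step of a 2.3-fold higher number from compound 3 to compound 4 (0.36 log units; beyond the scatter) is expected here. Compound 4 is therefore estimated at 720 nM, within 350 nM to 1500 nM.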

Compound 4, half-maximal inhibitory concentration: 128 nM
For compound 4 the middle estimate is 5.6-fold (0.75 log units) above the measured one; the measured number lies below the stated range.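

In this assay, bromo in place of methyl on the fused core gives a 2.4-fold lower number from compound 3 to compound 4 (0.39 log units; beyond the scatter), so the direction of the step on the open core did not carry over: the same swap raised the number there and lowers it here. The two steps differ by more than repeated measurements would explain: the same change on two cores in this assay, a 2.3-fold higher number (0.35 log units; beyond the scatter) from compound 1 to compound 2 and a 2.4-fold lower number (0.39 log units; beyond the scatter) from compound 3 to compound 4, 5.5-fold (0.74 log units) apart, beyond the scatter of two such steps This shows that, in this series, the step seen on one core is a poor guide to the step on the other, but two pairs of compounds cannot show why the cores differ or how a third core would behave.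

The compounds shown leave open how other groups in the same place, such as chloro, methoxy or an amine, would behave on each core. They also leave open whether a group other than bromo would reverse its step between the two cores in the same way.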